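Adding a Phenyl Next to the Aldehyde

A few compounds are considered here, and "the series" means these few. Any claim that something is new, unique, unknown or untested is made for them only; others in the source may bear on it.

Compound 3 `O=Cc1ccc2ccc(C(=O)O)ccc1-2` stands highest of the three compounds measured in an assay on cells for displacement of a labelled ligand from Orexin/Hypocretin receptor type 1 (Homo sapiens), read by scintillation counting, with stated times of 10 min and 90 min, tested at 10 uM (a lower number here means less inhibition, a higher number more inhibition at the concentration tested (going by the name of the read-out)), where compound 3 gives 37.8%. Its nearest neighbour is compound 2 `O=C(O)c1cccc2c(C(=O)c3ccccc3)cc(C(=O)c3ccc(C(F)(F)F)cc3)c-2c1`, which gives 18.3%, and the furthest is compound 1 `O=C(O)c1ccc2ccc(C(=O)c3ccccc3)c-2cc1`, which gives 11%. Among the compounds with values here, the one measured step that reaches compound 3 is a number 26.8 percentage points higher from compound 1 to compound 3 (beyond the scatter), a change at the carbonyl carbon. Compound 4 `O=Cc1cc(-c2ccccc2)c2ccc(C(=O)O)ccc1-2` differs from compound 3 by phenyl in place of hydrogen on an aromatic carbon. Within the data shown here, no measured step adds a phenyl on a ring carbon of the core, so the known step bears on it only loosely, and compound 2 shows that a larger molecule on this core can sit well below compound 3. A small step downward or none beyond the scatter is therefore expected, with compound 4 estimated at 30% (10% to 55%), meaning a number 7.8 percentage points lower from compound 3 to compound 4 (within the scatter).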

Compound 4, a percentage reported as inhibition, at one concentration (the size of the read-out at that concentration, not a potency): 16.2%
Compound 4: middle estimate off by 13.8 percentage points, on the high side; measured number inside the range.
By their numbers in this assay, from the lowest: compounds 1, 4 and 2 (each within the scatter of the next); then compound 3.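

In this assay, within the data shown here, phenyl in place of hydrogen on an aromatic carbon of the five-membered ring, two ring bonds from the ring atom that bears the formyl group, gives a number 21.6 percentage points lower from compound 3 to compound 4 (beyond the scatter) and is the first measured change on a ring carbon of the core. So with the formyl group kept, this carbon does not take a phenyl without a loss of inhibition at the concentration tested. Nothing available explains this loss. Going by these compounds, it remains open whether a methyl group or an amine at this carbon would lower the number as far, and whether phenyl here has the same effect when a benzoyl group stands in place of the formyl group.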